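From Methyl to Trifluoromethyl on the Aromatic Ring

A few compounds are considered here, and "the series" means these few. Any claim that something is new, unique, unknown or untested is made for them only; others in the source may bear on it.

Compounds measured in an in vitro assay on BTI-TN-5B1-4 cells for inhibition of Amine oxidase [flavin-containing] B (Homo sapiens), read by fluorescence; on this read-out higher numbers stand for weaker inhibition and lower numbers for stronger inhibition:
compound 1 `CC(C)CNC(=O)c1cc2ccccc2oc1=O`, 3270 nM
compound 2 `O=C(Nc1ccccc1)c1cc2ccccc2oc1=O`, 760 nM
compound 3 `Cc1cccc(NC(=O)c2cc3ccccc3oc2=O)c1`, 600 nM

Compound 3 carries the lowest of the three numbers, but compound 2 lies within the scatter of it (a 1.3-fold lower number from compound 2 to compound 3 (0.10 log units; within the scatter)), so no order between the two can be claimed; only compound 1 stands clearly apart (a 5.5-fold lower number from compound 1 to compound 3 (0.74 log units; beyond the scatter)). Compound 4 `O=C(Nc1cccc(C(F)(F)F)c1)c1cc2ccccc2oc1=O` differs from compound 3 by trifluoromethyl in place of methyl on an aromatic carbon. Within the data shown here, the one measured step that bears on this position is a 1.3-fold lower number from compound 2 to compound 3 (0.10 log units; within the scatter), which stayed within the scatter; the larger steps of a 4.3-fold lower number from compound 1 to compound 2 (0.63 log units; beyond the scatter) and a 5.5-fold lower number from compound 1 to compound 3 (0.74 log units; beyond the scatter) concern the group on the amide-type nitrogen and do not. Compound 4 is therefore expected to show no step beyond the scatter, no change at the digits printed from compound 3 to compound 4 (within the scatter). Compound 4 is estimated at 600 nM, between 250 nM and 1500 nM.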

Compound 4, half-maximal inhibitory concentration: 250 nM
Beside the measured number, compound 4's estimate is 2.4-fold (0.38 log units) above it; low and high end bracket the measured number.
By their numbers in this assay, from the lowest: compound 4; then compounds 3 and 2 (each within the scatter of the next); then compound 1.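

In this assay this aromatic carbon proves responsive after all, with a 2.4-fold lower number from compound 3 to compound 4 (0.38 log units; beyond the scatter) and with a 3.0-fold lower number from compound 2 to compound 4 (0.48 log units; beyond the scatter) as well, whereas methyl there had shown no step beyond the scatter. The position therefore tolerates a larger group than methyl, and the identity of the group placed there can change the number. Nothing given here accounts for the difference between methyl and trifluoromethyl.

The compounds shown leave open whether a chlorine atom or a methoxy group on this carbon would behave like trifluoromethyl or like methyl.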